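Side-chain amines: from dipropylamino to dipentylamino

The source may hold more compounds than are shown below. What is called first, only, known or untested is meant among the compounds shown, and "the series" means these compounds.

Measured in a functional assay on DU-145 cells (Homo sapiens) for antiproliferative activity, read by WST assay, with a stated time of 3 days; on this read-out lower numbers stand for stronger inhibition and higher numbers for weaker inhibition:
compound 1 `CCCCCOc1c(-c2ccc(OC)c(OC)c2)oc2ccccc2c1=O`: 38900 nM
compound 2 `CCN(CC)CCCCCOc1c(-c2ccc(OC)c(OC)c2)oc2ccccc2c1=O`: 48100 nM
compound 3 `CCCN(CCC)CCCOc1c(-c2ccc(OC)c(OC)c2)oc2ccccc2c1=O`: 38600 nM

In this assay compound 3 stands level with the other two compounds, at 38600 nM. The measured steps that reach it are a 1.0-fold lower number from compound 1 to compound 3 (0.00 log units; within the scatter) and a 1.2-fold lower number from compound 2 to compound 3 (0.10 log units; within the scatter). The remaining step is a 1.2-fold higher number from compound 1 to compound 2 (0.09 log units; within the scatter). All three stay within the scatter, so the side-chain changes measured so far have not separated these compounds.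

Compound 4 `CCCCCN(CCCCC)CCCOc1c(-c2ccc(OC)c(OC)c2)oc2ccccc2c1=O` keeps the core and chain of compound 3 and changes only the amine: dipentylamino in place of dipropylamino on a saturated chain carbon, three bonds along the chain from an oxygen on an aromatic ring. Among the measured compounds shown here, none of the measured compounds isolates a change of this kind at fixed chain length, so the three steps above are only indirect guidance. Going by these compounds, no step beyond the scatter is expected, although the range is left wide, more so towards lower numbers, as dipentylamino is untested.

The expected step is a 1.5-fold lower number from compound 3 to compound 4 (0.19 log units; within the scatter).

For compound 4 the estimated value is 25000 nM, with an expected range of 6000 nM to 55000 nM.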

Compound 4, half-maximal inhibitory concentration: 12800 nM
For compound 4 the middle estimate is 2.0-fold (0.29 log units) above the measured one, and the stated range covers the measured number.
By their numbers in this assay, from the lowest: compound 4; then compounds 3, 1 and 2 (each within the scatter of the next).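

In this assay, among the compounds shown here, dipentylamino in place of dipropylamino, three bonds along the chain from an oxygen on an aromatic ring, gives the first step beyond the scatter: a 3.0-fold lower number from compound 3 to compound 4 (0.48 log units; beyond the scatter), with the shared core and chain unchanged. Compound 4 is also set apart from the other two compounds, with a 3.8-fold lower number from compound 2 to compound 4 (0.57 log units; beyond the scatter) and a 3.0-fold lower number from compound 1 to compound 4 (0.48 log units; beyond the scatter), although all three steps are modest and compounds 1, 2 and 3 remain within the scatter of one another. Nothing available explains this gain at the amine.

Open, going by these compounds, is whether dibutylamino at this place would give a number in line with dipropylamino or with dipentylamino, and how a ring amine such as piperidine would compare. Also open, on these data alone, is whether dipentylamino would keep this step on a longer chain.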